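From fluoro to methoxy on compound 1

A few compounds are considered here, and "the series" means these few. Any claim that something is new, unique, unknown or untested is made for them only; others in the source may bear on it.

- compound 1 `Oc1nc(-c2cccc(F)c2)nc2ccccc12` gives > 20 ug/mL as a limit
- compound 2 `Oc1nc(-c2ccc3ccccc3c2)nc2ccccc12` gives 13 ug/mL as a number

In a functional assay on SK-MEL-2 cells (Homo sapiens) (on this read-out lower numbers stand for an effect already at smaller amounts and higher numbers for an effect only at larger amounts of compound), compound 1 gives > 20 ug/mL as a limit of the assay, not as a number. Compound 3 `COc1cccc(-c2nc(O)c3ccccc3n2)c1` has methoxy in place of fluoro on an aromatic carbon. Within the data shown here, no measured pair shows what this swap does in this assay, so no step beyond the usual scatter is expected. The estimated a number no higher from compound 1 to compound 3 (the limit leaves the size open) is therefore small in size and has no firm direction. Compound 3 is expected at 20 ug/mL, within an estimated range of 9 ug/mL to 45 ug/mL.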

Compound 3, concentration for half-maximal effect: > 20 ug/mL
Compound 3 was reported as a limit (the forecaster's own chance of this, stated with the estimate: 55%); the middle value sits exactly at the limit.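

Compound 1 and compound 3 are both reported as limits rather than numbers, so no step between them can be read: the limit of > 20 ug/mL in this assay, at which 2 of the 3 values shown sit.

On these data alone, whether methoxy in place of fluoro on an aromatic carbon changes the effect at all, and in which direction, stays open.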